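A few compounds are considered here, and "the series" means these few. Any claim that something is new, unique, unknown or untested is made for them only; others in the source may bear on it.

Compound 1 `c1cnc(-c2ccccc2OCC2=NCCN2)nc1`: 1260 nM
Compound 2 `c1ccc(-c2cnccn2)c(OCC2=NCCN2)c1`: 2.51 nM
Compound 3 `c1coc(-c2ccccc2OCC2=NCCN2)c1`: 1.26 nM

These numbers come from a functional assay for activation of Alpha-1A adrenergic receptor (Homo sapiens), read by calcium flux; on this read-out lower numbers stand for an effect already at smaller amounts and higher numbers for an effect only at larger amounts of compound. Compound 3 stands lowest of the three; one step towards it, a 2.0-fold lower number from compound 2 to compound 3 (0.30 log units; within the scatter), lies within the scatter, the other, a 1000-fold lower number from compound 1 to compound 3 (3.00 log units; beyond the scatter), far beyond it. Compound 4 `Cn1nccc1-c1ccccc1OCC1=NCCN1` is not yet measured and differs from compound 3 in one place: 1-methyl-1H-pyrazol-5-yl in place of furan-2-yl on an aromatic carbon. Both measured steps that exchange the ring at this carbon bear on the change, and they range from no shift to a very large one. Rings other than pyrimidin-2-yl have so far given low numbers in compound 2 and compound 3. Compound 4 is therefore expected to rise only moderately, a 7.9-fold higher number from compound 3 to compound 4 (0.90 log units; beyond the scatter). The estimate for compound 4 is 10 nM, between 1.5 nM and 100 nM.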

Compound 4, half-maximal effective concentration: 39.8 nM
Compound 4: middle estimate off by 4.0-fold (0.60 log units), on the low side; the measured number falls inside the stated range.
By their numbers in this assay, from the lowest: compounds 3 and 2 (each within the scatter of the next); then compound 4; then compound 1.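

At this aromatic carbon, 1-methyl-1H-pyrazol-5-yl adds a middle level, so the rings tested do not simply split into one high case and a low group. In this assay there is a 32-fold higher number from compound 3 to compound 4 (1.50 log units; beyond the scatter) and a 16-fold higher number from compound 2 to compound 4 (1.20 log units; beyond the scatter), yet also a 32-fold lower number from compound 1 to compound 4 (1.50 log units; beyond the scatter) as the other side of that middle place. No measurement shown accounts for these shifts. As far as these compounds go, whether the methyl group on this ring contributes to the rise stays open, and so does what a phenyl ring or a ring carrying an amine would give at this carbon.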